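Methylating the pyrrole nitrogen of a phenyl-bearing xanthine analogue

The compounds below may be only part of what the source reports. "The series", "measured", "known", "first", "only" and "open" are said of these compounds alone.

Measured compounds:
Compound 1 `CCCn1c(=O)c2[nH]ccc2n(CCC)c1=O` — 440 nM
Compound 2 `Cn1c(=O)c2c(cc(-c3ccccc3)n2C)n(C)c1=O` — 3600 nM
Compound 3 `Cn1c(=O)c2cc(-c3ccccc3)[nH]c2n(C)c1=O` — 3100 nM

In an assay for binding affinity to adenosine receptor A1 (Rattus norvegicus), in the presence of a further agent that is not named here (on this read-out lower numbers stand for stronger inhibition and higher numbers for weaker inhibition), compound 3 gives 3100 nM, the second highest of the three numbers. Its nearest neighbour is compound 2, whose 3600 nM lies within the scatter of compound 3, so the two cannot be ordered. Compound 1, with 440 nM, stands clearly lower than compound 3, beyond the scatter.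

Compound 4 `Cn1c(=O)c2cc(-c3ccccc3)n(C)c2n(C)c1=O` has not yet been measured in this assay. It differs from compound 3 in one place: methyl in place of hydrogen on an aromatic nitrogen. Within the data shown here, no step between measured compounds reproduces this change. Among the measured compounds shown here, the only guide is that compound 2 and compound 3, which differ in more than one place including the presence of a methyl on a ring nitrogen, give values within the scatter of each other.

Compound 4 is therefore expected to show a step of a 1.3-fold higher number from compound 3 to compound 4 (0.11 log units; within the scatter) that stays within the scatter, with a small lean towards a higher number. The estimate for compound 4 in this assay is 4000 nM, within a range from 1500 nM to 12000 nM.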

Compound 4, inhibition constant: 11000 nM
The estimate for compound 4 lay 2.8-fold (0.44 log units) below the measured number; low and high end bracket the measured number.
By their numbers in this assay, from the lowest: compound 1; then compounds 3 and 2 (each within the scatter of the next); then compound 4.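

In this assay, methyl in place of hydrogen on the aromatic nitrogen, next to the ring atom that bears a phenyl group, gives a 3.5-fold higher number from compound 3 to compound 4 (0.55 log units; beyond the scatter). Among these compounds, this is the only step here between compounds that differ in one place, so it gives the first direct reading for this nitrogen: the number rises beyond the usual scatter, though only modestly. Nothing in the data at hand bears on why the number rises.

Going by these compounds, it remains open whether the size of the step belongs to methyl in particular, or whether an ethyl chain or a 2-hydroxyethyl chain on this nitrogen would give a similar number. Also open, on these data alone, is whether the same change would give a similar step on a compound without the phenyl group.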